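The source may report more compounds than this note shows. Statements on the series, on what has been measured and on what is new or still open speak of the compounds shown alone.

In a functional assay (aorta) with Rattus norvegicus as the target, in the presence of a further agent that is not named here (a lower number here means that less compound is needed, a higher number that more compound is needed for the effect), compound 1 `COC(=O)C1=C(C)N=C(C)/C(=C(/O)OC)C1c1ccccc1OCc1c(C)no[n+]1[O-]` gives 78 nM, the middle of three numbers: compound 2 `COC(=O)C1=C(C)N=C(C)/C(=C(/O)OC)C1c1cccc(OCc2nonc2C#N)c1` stands higher at 310 nM, and compound 3 `COC(=O)C1=C(C)N=C(C)/C(=C(/O)OC)C1c1cccc(OCc2c(C#N)no[n+]2[O-])c1` lower at 11 nM. Compound 4 `COC(=O)C1=C(C)N=C(C)/C(=C(/O)OC)C1c1ccccc1OCc1c(C#N)no[n+]1[O-]` carries cyano in place of methyl on an aromatic carbon. For the measured compounds named here, no measured step makes this exchange. The closest evidence is a 28-fold lower number from compound 2 to compound 3 (1.45 log units; beyond the scatter), a large step in which both compounds carry cyano, so it does not isolate the exchange. Going by the values given here, it shows only that a cyano-bearing compound can reach a low number. A moderate step to a lower number is therefore expected in this assay, with wide uncertainty. For compound 4 the estimated value is 25 nM, with an expected range from 6 nM to 100 nM. This expectation amounts to a 3.1-fold lower number from compound 1 to compound 4 (0.49 log units; beyond the scatter).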

Compound 4, half-maximal effective concentration: 9.4 nM
The estimate for compound 4 lay 2.7-fold (0.42 log units) above the measured number; measured number inside the range.
By their numbers in this assay, from the lowest: compounds 4 and 3 (each within the scatter of the next); then compound 1; then compound 2.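

Read directly for the first time in this assay, cyano in place of methyl on this aromatic carbon, next to the ring atom that bears a large group, gives an 8.3-fold lower number from compound 1 to compound 4 (0.92 log units; beyond the scatter) as a modest step beyond the scatter. The earlier compounds shown here carried no pair that isolated this exchange at this position. No measurement at hand accounts for the step.

Going by these compounds, what an amine, a carboxylic acid or a longer alkyl chain on this same carbon would give remains open. So does whether the exchange would give a step of similar size in another compound of the series.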